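The source may report more compounds than this note shows. Statements on the series, on what has been measured and on what is new or still open speak of the compounds shown alone.

Of the compounds shown here, three have been measured so far in a functional assay on FTC-133 cells (Homo sapiens) for cytotoxicity, read by MTT assay, with a stated time of 24 h; on this read-out higher numbers stand for weaker inhibition and lower numbers for stronger inhibition.

Compound 1 `COc1ccc(-c2cn([C@H]3C[C@H](CO)N(C)O3)nn2)cc1` gives 7000 nM.
Compound 2 `CCCCCc1ccc(-c2cn([C@H]3C[C@H](CO)N(C)O3)nn2)cc1` gives 3950 nM.
Compound 3 `COc1ccc(-c2cn([C@@H]3C[C@H](CO)N(C)O3)nn2)cc1` gives 6480 nM.

Compound 1 and compound 2 share one core and differ by a single change: pentyl in place of methoxy on an aromatic carbon. In this assay this change gave a 1.8-fold lower number from compound 1 to compound 2 (0.25 log units; within the scatter). Compound 1 and compound 3 differ in another way: the two compounds have the same atoms and bonds and differ only in configuration as drawn: 1 of 2 stereo elements differ; a stereocentre at a saturated ring carbon is drawn R in compound 1 and S in compound 3. The step of a 1.1-fold lower number from compound 1 to compound 3 (0.03 log units; within the scatter) is small, which fits (the fact that compounds 1 and 3 differ only in the configuration as drawn).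

Compound 4 `CCCCCc1ccc(-c2cn([C@@H]3C[C@H](CO)N(C)O3)nn2)cc1` has not yet been measured. It stands to compound 3 as compound 2 stands to compound 1. The change is pentyl in place of methoxy on an aromatic carbon, the same change as before, made on a core that differs from the core of compound 1 only in the configuration described above. A step of similar size is expected here, a 1.8-fold lower number from compound 3 to compound 4 (0.24 log units; within the scatter), because the earlier step of a 1.8-fold lower number from compound 1 to compound 2 (0.25 log units; within the scatter) was modest and because compound 1 and compound 3 sit close together at a 1.1-fold lower number from compound 1 to compound 3 (0.03 log units; within the scatter). Compound 4 is therefore estimated to give 3700 nM in this assay, most likely between 2000 nM and 6800 nM.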

Compound 4, half-maximal inhibitory concentration: 4490 nM
Beside the measured number, compound 4's estimate is 1.2-fold (0.08 log units) below it, and the stated range covers the measured number.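

In this assay the same pentyl-for-methoxy change on the second core gives a 1.4-fold lower number from compound 3 to compound 4 (0.16 log units; within the scatter) and so matches the earlier step as closely as such data can: the same change on two cores in this assay, a 1.8-fold lower number (0.25 log units; within the scatter) from compound 1 to compound 2 and a 1.4-fold lower number (0.16 log units; within the scatter) from compound 3 to compound 4, 1.2-fold (0.09 log units) apart, within the scatter of two such steps. The two pentyl compounds also sit close together, with a 1.1-fold higher number from compound 2 to compound 4 (0.06 log units; within the scatter) as the step between them, which fits how little separates them: the fact that compounds 2 and 4 differ only in the configuration as drawn. Yet every one of these steps lies within the usual scatter, so the agreement shows only that the change stays small on both cores; it does not show that pentyl truly lowers the number on either core, or that the same would hold on a different core.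

The compounds shown leave open what other groups would do at this place, such as a longer chain, an amine or a carboxylic acid. They also leave open whether any change in this series can produce a step beyond the scatter, and whether the two configurations would then differ.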